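From cyclopentylamino to propoxy at the assay limit

The source may report more compounds than this note shows. Statements on the series, on what has been measured and on what is new or still open speak of the compounds shown alone.

In an ADME assay on HFF cells (Homo sapiens) for cytotoxicity, with a stated time of 8 days (a lower number here means that less compound is tolerated, a higher number that more compound is tolerated), compound 1 `CC(C)CSc1nc(N)nc2c1ncn2/C=C1/CC1(CO)CO` gives > 300000 nM as a limit of the assay. Compound 2 `Nc1nc(NC2CCCC2)c2ncn(/C=C3/CC3(CO)CO)c2n1` gives > 300000 nM as a limit too, so its standing has no exact number. Compound 3 `CCCOc1nc(N)nc2c1ncn2/C=C1/CC1(CO)CO` carries propoxy in place of cyclopentylamino on an aromatic carbon and has yet to be measured. Among the measured compounds shown here, the one measured step that the two limits leave unreadable from compound 1 to compound 2 gives no size, and the evidence stops at the limit of > 300000 nM in this assay, at which 2 of the 2 values shown sit, without a number. No step beyond the scatter is expected, and the estimated change is a number no higher from compound 2 to compound 3 (the limit leaves the size open) for this swap. Compound 3 is expected at 300000 nM with an estimated range from 100000 nM to 500000 nM in this read-out.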

Compound 3, half-maximal cytotoxic concentration: > 300000 nM
Compound 3 was reported as a limit (the forecaster's own chance of this, stated with the estimate: 75%); the middle value lies on the limit itself.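

Compound 3 is also reported only as a limit, so no step among compound 1, compound 2 and compound 3 can be read in this assay: the limit of > 300000 nM in this assay, at which 3 of the 3 values shown sit.

The compounds shown leave open how these three compare and at what concentration any of them would become cytotoxic.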